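Working notes: dimethylamino in place of methoxy

The source may report more compounds than this note shows. Statements on the series, on what has been measured and on what is new or still open speak of the compounds shown alone.

In a functional assay on K562 cells (Homo sapiens) for cytotoxicity, read by sulforhodamine B assay (a lower number here means a stronger inhibitor of growth, a higher number a weaker inhibitor of growth), compound 1 (`CC1=CC[C@@H]([C@@](C)(O)CCCC(C)(C)NC(=S)NN)CC1`) gives 20 nM. Compound 2 (`CC1=CC[C@@H]([C@@](C)(O)CCCC(C)(C)NC(=S)N/N=C\c2ccccc2)CC1`) gives 130 nM, and compound 3 (`COc1ccc(/C=N\NC(=S)NC(C)(C)CCC[C@](C)(O)[C@@H]2CC=C(C)CC2)cc1`) gives 220 nM. Compound 3 therefore stands level with compound 2 within the scatter, and both sit clearly on the weaker side of compound 1. The two steps away from compound 1 are sizeable: a 6.5-fold higher number from compound 1 to compound 2 (0.81 log units; beyond the scatter), and an 11-fold higher number from compound 1 to compound 3 (1.04 log units; beyond the scatter).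

Compound 4 (`CC1=CC[C@@H]([C@@](C)(O)CCCC(C)(C)NC(=S)N/N=C\c2ccc(N(C)C)cc2)CC1`) is the next to be read. The change is dimethylamino in place of methoxy on an aromatic carbon. For the measured compounds named here, no measured step makes this exact swap. The two large steps replace one nitrogen atom with a whole aromatic group, so they bear on it only weakly. The closest guide is the change on the aromatic ring itself, a 1.7-fold higher number from compound 2 to compound 3 (0.23 log units; within the scatter), which stays within the scatter. A change at this place on the ring has so far left the number essentially unmoved, though that rests on a single pair.

The expected move is a 1.1-fold lower number from compound 3 to compound 4 (0.04 log units; within the scatter), so no step beyond the scatter is anticipated, in either direction. The estimate for compound 4 is 200 nM, with an expected range of 90 nM to 450 nM.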

Compound 4, concentration for 50% growth inhibition: 80 nM
For compound 4 the middle estimate is 2.5-fold (0.40 log units) above the measured one; the measured number lies below the stated range.
By their numbers in this assay, from the lowest: compound 1; then compounds 4, 2 and 3 (each within the scatter of the next, the first and the last beyond it).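

Working notes on the result: in this assay, the group on this aromatic carbon, para to a large group, can move the number beyond the scatter (a 2.8-fold lower number from compound 3 to compound 4 (0.44 log units; beyond the scatter)), whereas the only earlier change at this place stayed within it (a 1.7-fold higher number from compound 2 to compound 3 (0.23 log units; within the scatter)). Against the ring carrying hydrogen at this place, the dimethylamino change also stays within the scatter (a 1.6-fold lower number from compound 2 to compound 4 (0.21 log units; within the scatter)), so neither substituent separates from compound 2 and the one clear separation lies between 4-methoxyphenyl and 4-(dimethylamino)phenyl themselves. No measurement at hand accounts for that separation.

As far as these compounds go, whether a fluorine or a nitro group on the same aromatic carbon would track with methoxy or with dimethylamino remains open, as does whether a free amino group or a pyrrolidine ring would behave like dimethylamino. Also open, from the compounds shown here alone, is whether any group at this place can bring the series back to the level of compound 1 (20 nM) or whether the aromatic group itself keeps these compounds on the weaker side.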